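Swapping Methyl for Chloro on the Sulfonyl Aryl Ring

The source may hold more compounds than are shown below. What is called first, only, known or untested is meant among the compounds shown, and "the series" means these compounds.

Measured compounds:
- compound 1 `Cc1ccc(S(=O)(=O)N2C/C(=C\c3ccccc3F)C(=O)/C(=C/c3ccccc3F)C2)cc1` gives 14200 nM in a functional assay on HepG2 cells (Homo sapiens) for cytotoxicity, read by MTT assay, with a stated time of 24 h; on this read-out lower numbers stand for stronger inhibition and higher numbers for weaker inhibition
- compound 2 `O=C1/C(=C/c2ccccc2F)CN(S(=O)(=O)c2ccc(O[N+](=O)[O-])cc2)C/C1=C\c1ccccc1F` gives 16500 nM in this assay

Compound 1 has the lower of the two numbers, but only just: the step of a 1.2-fold higher number from compound 1 to compound 2 (0.07 log units; within the scatter) lies within the scatter, so the two compounds cannot be told apart on these data. Compound 3 `O=C1/C(=C/c2ccccc2F)CN(S(=O)(=O)c2ccc(Cl)cc2)C/C1=C\c1ccccc1F` differs from compound 1 by chloro in place of methyl on an aromatic carbon. For the measured compounds named here, the only measured step that bears on this position is the one from compound 1 to compound 2, where the methyl was replaced by a nitrooxy group, and that exchange left the number essentially unchanged. With one small group swapped for another at the same place, no step beyond the scatter is expected in this assay. Compound 3 is therefore estimated at 14000 nM, with a range from 7000 nM to 28000 nM. The expected step is a 1.0-fold lower number from compound 1 to compound 3 (0.01 log units; within the scatter).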

Compound 3, half-maximal inhibitory concentration: 10900 nM
Estimate against measurement, compound 3: 1.3-fold (0.11 log units) above, within the range that was stated.
By their numbers in this assay, from the lowest: compounds 3, 1 and 2 (each within the scatter of the next).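

Chloro in place of methyl gives a 1.3-fold lower number from compound 1 to compound 3 (0.11 log units; within the scatter), and chloro in place of nitrooxy gives a 1.5-fold lower number from compound 2 to compound 3 (0.18 log units; within the scatter). With a third group on this aromatic carbon of the shared core, all the measured exchanges here now stay within the scatter of this assay, so the earlier result no longer rests on a single pair. On these data, methyl, nitrooxy and chloro cannot be told apart at this position, and nothing available here explains that result.

From the compounds shown here alone, whether an amine, a carboxylic acid or a longer chain on this aromatic carbon would shift the number beyond the scatter remains open. Going by these compounds, it is also open whether chloro and methyl would still match if another part of the shared core were changed.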